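The source may hold more compounds than are shown below. What is called first, only, known or untested is meant among the compounds shown, and "the series" means these compounds.

Working notes on the thiosemicarbazide series.

Of the compounds shown here, three have been measured so far in a functional assay on MCF7 cells (Homo sapiens) for cytotoxicity, read by MTT assay, with a stated time of 72 h, tested at 1 uM; a lower number here means less inhibition of growth, a higher number more inhibition of growth at the concentration tested. Compound 1 `N/C(=N\NC(=S)N1CCOCC1)c1ccccn1` gives 14.7%. Compound 3 `Cc1cccc(/C(N)=N/NC(=S)N2CCOCC2)n1` gives 11.7%. Compound 2 `Cc1ccnc(/C(N)=N/NC(=S)N2CCN(c3ccccn3)CC2)c1` gives 21%. The three numbers lie close together, and no ordering among them is claimed.

Among the compounds with values here, the one counted step among the measured compounds is hydrogen in place of methyl on an aromatic carbon, which in this assay reads a number 3 percentage points higher from compound 3 to compound 1 (within the scatter). Compound 2 and compound 3 differ in more than one place; the difference between their cores is not broken down here.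

Compound 4 `N/C(=N\NC(=S)N1CCN(c2ccccn2)CC1)c1ccccn1` has not yet been measured. It differs from compound 2 by hydrogen in place of methyl on an aromatic carbon. This is the same kind of change as that from compound 3 to compound 1, but the place is not identical: in the measured pair the carbon is next to the ring nitrogen, whereas in compound 4 it is opposite the ring nitrogen.

Given that the measured instance of this change produced only a number 3 percentage points higher from compound 3 to compound 1 (within the scatter), the step from compound 2 to compound 4 is expected to be similarly small, a number 2 percentage points higher from compound 2 to compound 4 (within the scatter). Compound 4 is therefore estimated at 23%, with a range from 10% to 36%.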

Compound 4, percent growth inhibition at one concentration: 36%
Compound 4: the middle estimate sits 13 percentage points below what was measured; the measured number falls inside the stated range.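

Hydrogen in place of methyl, here 4-methylpyridin-2-yl to pyridin-2-yl, reads in this assay as a number 15 percentage points higher from compound 2 to compound 4 (beyond the scatter). Set beside the earlier step, this gives no ground for saying that the change behaves differently on the two cores: the same change on two cores in this assay, a number 3 percentage points higher (within the scatter) from compound 3 to compound 1 and a number 15 percentage points higher (beyond the scatter) from compound 2 to compound 4, 12 percentage points apart, within the scatter of two such steps. Nor does it show that the size of the step carries over from one core to another: only two pairs are at hand, the methyl does not stand at the same place in them, and it is opposite the ring nitrogen only in compound 2.

The compounds shown leave open how other groups on this aromatic carbon would read, such as a methoxy group, a chlorine atom or an amine; only methyl and hydrogen appear there. Also open, as far as these compounds go, is whether either step would hold on other cell lines or at other concentrations, with growth inhibition here read at a single concentration on one cell line.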